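The source may hold more compounds than are shown below. What is called first, only, known or untested is meant among the compounds shown, and "the series" means these compounds.

Measured so far in an assay on isolated protein with retinoic acid receptor gamma (Homo sapiens) as the target, read by TR-FRET, with a stated time of 4 h; a higher number here means that more compound is needed for the effect, a lower number that less compound is needed: compound 1 `CCOC(=O)c1ccc(-c2nc(-c3ccc4c(c3)C(C)(C)CCC4(C)C)c(C)s2)cc1` gives 847 nM; compound 2 `CCOCCOc1nc(-c2ccc(C(=O)O)cc2)sc1C` gives 141 nM.

Compound 1 stands highest of the two numbers in this assay; its nearest neighbour, compound 2, sits well outside the scatter at the lower number. Compound 3 `Cc1sc(-c2ccc(C(=O)O)cc2)nc1-c1ccc2c(c1)C(C)(C)CCC2(C)C` is not yet measured. It differs from compound 1 by hydrogen in place of ethyl on an oxygen next to a carbonyl group, the same ethoxycarbonyl-to-carboxy change that compound 2 already carries. Among the compounds with values here, no matched step between measured compounds exists for this change. Within the data shown here, a step toward a lower number is expected, beyond the scatter, given that compound 2 as the only measured carboxy compound gives 141 nM. Compound 3 is expected at 120 nM, range 30 nM to 450 nM, a step of a 7.1-fold lower number from compound 1 to compound 3 (0.85 log units; beyond the scatter).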

Compound 3, half-maximal effective concentration: 98.9 nM
Estimate against measurement, compound 3: 1.2-fold (0.08 log units) above, within the range that was stated.
By their numbers in this assay, from the lowest: compounds 3 and 2 (each within the scatter of the next); then compound 1.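

Within the data shown here, this is the first matched reading of the ethoxycarbonyl-to-carboxy change: on the shared core, hydrogen in place of ethyl on an oxygen next to a carbonyl group gives an 8.6-fold lower number from compound 1 to compound 3 (0.93 log units; beyond the scatter) in this assay and a step beyond the scatter. The direction at this position is therefore now read directly within one matched pair, not inferred from a different compound. Nothing measured here accounts for the size of this step.

Going by these compounds, whether a methyl ester or a primary amide at this position would sit closer to compound 1 or to compound 3 remains open. So does whether the same change gives a similar step on any other core.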